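Exchanging the group on the carbonyl carbon

This account rests on a few compounds, and the source may have more. Where it says the series, first, only, none or still open, it means among the compounds named here.

Measured in an ADME assay on MDCK cells (Canis lupus familiaris) for permeability, in the apical to basolateral direction; on this read-out lower numbers stand for lower permeability and higher numbers for higher permeability:
Compound 1 `O=C(NCc1ccc(S(=O)(=O)c2cc(F)cc(F)c2)cc1)c1cc2ccncc2o1`: 14 10^-6 cm/s
Compound 2 `O=C(NCc1ccc(S(=O)(=O)c2cc(F)cc(F)c2)cc1)c1cc2cnccc2[nH]1`: 13 10^-6 cm/s
Compound 3 `O=C(NCc1ccc(S(=O)(=O)N2CCOCC2)cc1)c1cc2ccncc2o1`: 15 10^-6 cm/s

The three compounds sit close together. Compound 3, at 15 10^-6 cm/s, lies within the scatter of both compound 1 and compound 2.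

Compound 4 `O=C(NCc1ccc(S(=O)(=O)N2CCOCC2)cc1)c1cc2cnccc2[nH]1` has not yet been measured. It departs from compound 3 at a single place, on a carbonyl carbon whose other neighbours are an amide-type nitrogen: a group of 9 heavy atoms (7 carbon, 2 nitrogen; one five-membered aromatic ring with 1 hetero atom, one six-membered aromatic ring with 1 hetero atom) in place of a group of 9 heavy atoms (7 carbon, 1 nitrogen, 1 oxygen; one five-membered aromatic ring with 1 hetero atom, one six-membered aromatic ring with 1 hetero atom), on a carbonyl carbon.

The same exchange has already been measured with 3,5-difluorophenyl on the sulfonyl sulfur, and it gave a 1.1-fold lower number from compound 1 to compound 2 (0.03 log units; within the scatter). Putting morpholin-4-yl in place of 3,5-difluorophenyl on that sulfur gave a 1.1-fold higher number from compound 1 to compound 3 (0.03 log units; within the scatter). Neither step leaves the scatter, so the exchange is not expected to move this assay beyond the scatter on the morpholin-4-yl compound, although this rests on a single precedent. The expected step is a 1.1-fold lower number from compound 3 to compound 4 (0.03 log units; within the scatter). Compound 4 is estimated at 14 10^-6 cm/s, with an expected range of 8 10^-6 cm/s to 23 10^-6 cm/s.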

Compound 4, apparent permeability: 1.3 10^-6 cm/s
For compound 4 the middle estimate is 11-fold (1.03 log units) above the measured one; the measured number lies below the stated range.
By their numbers in this assay, from the lowest: compound 4; then compounds 2, 1 and 3 (each within the scatter of the next).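

Among the compounds shown here, the exchange on the carbonyl carbon does not act independently of the group on the sulfonyl sulfur in this assay, which the earlier compounds could not show, since the two cores give clearly different steps: the same change on two cores in this assay, a 1.1-fold lower number (0.03 log units; within the scatter) from compound 1 to compound 2 and a 12-fold lower number (1.06 log units; beyond the scatter) from compound 3 to compound 4, 11-fold (1.03 log units) apart, beyond the scatter of two such steps. Read the other way, morpholin-4-yl in place of 3,5-difluorophenyl on that sulfur gives a 10-fold lower number from compound 2 to compound 4 (1.00 log units; beyond the scatter), so this change also depends on the group on the carbonyl carbon: the same change on two cores in this assay, a 1.1-fold higher number (0.03 log units; within the scatter) from compound 1 to compound 3 and a 10-fold lower number (1.00 log units; beyond the scatter) from compound 2 to compound 4, 11-fold (1.03 log units) apart, beyond the scatter of two such steps. Neither group brings the low number alone, as compound 2 carries the entering group and compound 3 carries morpholin-4-yl, and the step of a 12-fold lower number from compound 3 to compound 4 (1.06 log units; beyond the scatter) appears only when the two meet in compound 4.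

The compounds shown leave open whether another group on the sulfonyl sulfur, such as piperidin-1-yl or dimethylamino, would behave like morpholin-4-yl. They also do not separate the hydrogen-bond donor that enters from the other differences between the two groups on the carbonyl carbon.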